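A few compounds are considered here, and "the series" means these few. Any claim that something is new, unique, unknown or untested is made for them only; others in the source may bear on it.

In a functional assay on A549 cells (Homo sapiens) for cytotoxicity, read by colorimetric assay and MTT assay (on this read-out lower numbers stand for stronger inhibition and higher numbers for weaker inhibition), compound 1 (`COc1cc(OC)c2cc(-c3ccccc3)c(O)nc2c1`) gives 10000 nM. Compound 2 (`CCOC(=O)Cn1c(=O)c(-c2ccc(OC)cc2)cc2c(OC)cc(OC)cc21`) gives 10000 nM, level with compound 1 within the scatter, so the two cannot be told apart on these numbers.

Compound 3 (`COc1ccc(-c2cc3c(OC)cc(OC)cc3n(CCCC#N)c2=O)cc1`) is still to be measured. It differs from compound 2 on a saturated chain carbon bound to an aromatic nitrogen: 2-cyanoethyl in place of ethoxycarbonyl on a saturated chain carbon bound to an aromatic nitrogen. Cut one bond further out, the same difference reads (ethoxycarbonyl)methyl to 3-cyanopropyl.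

For the measured compounds named here, the series offers no measured step between compounds that differ in one place, so nothing here sizes this change directly. Going by the values given here, only two values are available, and they sit level, which gives no direction to expect. The expectation in this assay is therefore for no step beyond the scatter, and it rests on compound 2 at 10000 nM. The estimated step is no change at the digits printed from compound 2 to compound 3 (within the scatter). Compound 3 is expected at 10000 nM, with an estimated range of 3000 nM to 30000 nM.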

Compound 3, half-maximal inhibitory concentration: 10000 nM
Beside the measured number, compound 3's estimate shows no gap at the digits printed; the measured number falls inside the stated range.
By their numbers in this assay, from the lowest: compounds 1, 2 and 3 (each within the scatter of the next).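

In this assay, for the compounds shown here, the change to 2-cyanoethyl in place of ethoxycarbonyl on a saturated chain carbon bound to an aromatic nitrogen reads no change at the digits printed from compound 2 to compound 3 (within the scatter), the first measured step between compounds that differ in one place. At this position, then, a group with 5 heavy atoms and 2 hydrogen-bond acceptors and a group with 4 heavy atoms and 1 hydrogen-bond acceptor cannot be told apart on this read-out, and a double bond outside aromatic rings gives way to a triple bond with the same outcome. Nothing measured on these compounds bears on why the number holds.

Still open, going by these compounds, is whether an amine or a free carboxylic acid at the end of this chain, or a longer chain, would give a number different from compound 3 at 10000 nM in this assay. Also open, on these data alone, is whether the same change at this position would read the same with a different group elsewhere on the shared core.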